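Lengthening the sulfonyl chain from propyl to butyl

The source may report more compounds than this note shows. Statements on the series, on what has been measured and on what is new or still open speak of the compounds shown alone.

Compound 1 `CS(=O)(=O)N1CCC2(CC1)OOC1(CCCCCC1)OO2` gives > 100 ug/mL as a limit
Compound 2 `CCCS(=O)(=O)N1CCC2(CC1)OOC1(CCCCCC1)OO2` gives > 100 ug/mL as a limit

Both readings come from a functional assay on Huh-7 cells (Homo sapiens) for cytotoxicity, read by MTT assay, with a stated time of 72 h (a lower number here means that less compound is tolerated, a higher number that more compound is tolerated), and neither is an exact number. From the compounds shown here alone, compound 2 stands at > 100 ug/mL as a limit, so its true value remains unknown. Compound 1 and compound 2 share a single reading (the limit of > 100 ug/mL in this assay, at which 2 of the 2 values shown sit) and cannot be put in order.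

Compound 3 `CCCCS(=O)(=O)N1CCC2(CC1)OOC1(CCCCCC1)OO2` differs from compound 2 by one change: methyl in place of hydrogen on a saturated chain carbon, three bonds along the chain from a sulfonyl sulfur which reads propyl to butyl. Among the measured compounds shown here, the one measured step that bears on this is a step that the two limits leave unreadable from compound 1 to compound 2 and it offers no size or direction to carry over. The expected step is a number no higher from compound 2 to compound 3 (the limit leaves the size open) and it is estimated to stay within the usual scatter, with no direction foreseen. Compound 3 is expected near 100 ug/mL with an estimated range of 50 ug/mL to 200 ug/mL.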

Compound 3, half-maximal cytotoxic concentration: > 100 ug/mL
Compound 3 was reported as a limit; the forecaster's own chance of this, stated with the estimate: 75%; the middle value sits exactly at the limit.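

In this assay compound 3 gives > 100 ug/mL as a limit. No step among compound 1, compound 2 and compound 3 can be read, as all three share one reading: the limit of > 100 ug/mL in this assay, at which 3 of the 3 values shown sit.

From the compounds shown here alone, what stays open is the true level each compound tolerates, and whether the sulfonyl chain changes it at all.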